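Replacing the methylpyrazole of compound 2 with 3-cyanophenyl

The source may report more compounds than this note shows. Statements on the series, on what has been measured and on what is new or still open speak of the compounds shown alone.

Measured in a functional assay on EBC-1 cells (Homo sapiens) for antiproliferative activity, with a stated time of 72 h (on this read-out lower numbers stand for stronger inhibition and higher numbers for weaker inhibition), so far:
Compound 1 `Cn1cc(-c2cc(C(F)(F)F)c3ncc(Cc4ccc5ncccc5c4)n3c2)cn1` gives "not determined" (no result reported)
Compound 2 `Cn1cc(-c2cc(F)c3ncc(Cc4ccc5ncccc5c4)n3c2)cn1` gives 0.27 nM

Going by the values given here, compound 2 at 0.27 nM holds the only number in this small set, and compound 1 offers no result to set against it. Compound 3 `N#Cc1cccc(-c2cc(F)c3ncc(Cc4ccc5ncccc5c4)n3c2)c1` keeps the shared core and the fluoro group of compound 2. Among the compounds with values here, its one change is 3-cyanophenyl in place of 1-methyl-1H-pyrazol-4-yl on an aromatic carbon at the aromatic carbon meta to the fluoro group. Within the data shown here, no measured pair shows what such an exchange does in this assay and the expectation has only the structural change to go on. Starting from compound 2 at 0.27 nM a higher number is expected, meaning a moderate step towards weaker inhibition that could still end within the scatter. Estimated this way, the expected move is a 3.7-fold higher number from compound 2 to compound 3 (0.57 log units; beyond the scatter) in size. For compound 3 the estimated value is 1 nM with an expected range from 0.2 nM to 6 nM for repeated measurements.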

Compound 3, half-maximal inhibitory concentration: 107 nM
The estimate for compound 3 lay 110-fold (2.03 log units) below the measured number, and the stated range ends below it.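

In this assay, going by these compounds alone, the exchange of 1-methyl-1H-pyrazol-4-yl for 3-cyanophenyl gives a 400-fold higher number from compound 2 to compound 3 (2.60 log units; beyond the scatter) and provides the first measured comparison in this set. With the shared core and the fluoro group held constant, it shows that activity at this aromatic carbon, meta to a fluoro group, depends strongly on the group it carries, and that 3-cyanophenyl is far less well tolerated here than 1-methyl-1H-pyrazol-4-yl. No measured information on any property of these groups is available to account for a step of this size.

The compounds shown leave open whether the loss follows from the carbon-only six-membered ring itself or from its nitrile, a question that an unsubstituted phenyl, a pyridyl or a 4-cyanophenyl group at the same carbon would help to separate, and whether a smaller change such as 1H-pyrazol-4-yl or 1-ethyl-1H-pyrazol-4-yl would keep the activity of compound 2. The trifluoromethyl group of compound 1 also cannot yet be compared with the fluoro group of compound 2, as compound 1 gives "not determined" (no result reported) and that step cannot be read.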